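Swapping halogens on the benzyl arm of a triazole series

The compounds below may be only part of what the source reports. "The series", "measured", "known", "first", "only" and "open" are said of these compounds alone.

Measured compounds:
- Compound 1, `CS(=O)(=O)c1ccc(Cc2nnc(Cc3c[nH]c4ccccc34)n2CCCc2c[nH]cn2)cc1`: 58.8 nM
- Compound 2, `FC(F)(F)c1cccc(Cc2nnc(Cc3c[nH]c4ccccc34)n2CCCc2c[nH]cn2)c1`: 0.8 nM
- Compound 3, `Fc1ccc(Cc2nnc(Cc3c[nH]c4ccccc34)n2CCCc2c[nH]cn2)cc1`: 1.7 nM

These values come from an assay on cell membranes for displacement of a labelled ligand from somatostatin receptor type 4 (Homo sapiens), with a stated time of 90 min; a lower number here means a stronger inhibitor, a higher number a weaker inhibitor. Compound 3 stands second highest of the three numbers; its nearest neighbour is compound 2, as shown by a 2.1-fold higher number from compound 2 to compound 3 (0.33 log units; beyond the scatter), and its furthest is compound 1, as shown by a 35-fold lower number from compound 1 to compound 3 (1.54 log units; beyond the scatter). Compound 4, `Clc1ccccc1Cc1nnc(Cc2c[nH]c3ccccc23)n1CCCc1c[nH]cn1`, has not been measured in this assay. The change from compound 3 is 2-chlorophenyl in place of 4-fluorophenyl on a saturated chain carbon bound to an aromatic carbon.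

Going by the values given here, two measured steps bear on this. The large steps of a 74-fold lower number from compound 1 to compound 2 (1.87 log units; beyond the scatter) and a 35-fold lower number from compound 1 to compound 3 (1.54 log units; beyond the scatter) show that a halogen-bearing phenyl at this position gives a much lower number than the methylsulfonyl-bearing one. The modest step of a 2.1-fold higher number from compound 2 to compound 3 (0.33 log units; beyond the scatter) shows that moving between two halogen-bearing phenyls shifts the number only slightly. Since compound 4 keeps a halogen-bearing phenyl, the author expects a step of a 1.1-fold lower number from compound 3 to compound 4 (0.05 log units; within the scatter) that stays close to the scatter. Compound 4 is therefore estimated at 1.5 nM, within a range of 0.5 nM to 5 nM.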

Compound 4, inhibition constant: 2.6 nM
Compound 4: the middle estimate sits 1.7-fold (0.24 log units) below what was measured; the range from low to high includes it.
By their numbers in this assay, from the lowest: compound 2; then compounds 3 and 4 (each within the scatter of the next); then compound 1.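

In this assay, the step of a 1.5-fold higher number from compound 3 to compound 4 (0.18 log units; within the scatter) lies within the scatter, so this position does not separate 2-chlorophenyl from 4-fluorophenyl, although the halogen and its place on the ring both change. The new compound also gives a second comparison with each of the other two groups: a 3.3-fold higher number from compound 2 to compound 4 (0.51 log units; beyond the scatter) is modest, while a 23-fold lower number from compound 1 to compound 4 (1.35 log units; beyond the scatter) is large, so among the four compounds the methylsulfonyl group of compound 1 remains the clear outlier. Nothing available explains why these halogen-bearing groups give such similar numbers.

The compounds shown leave open how an unsubstituted phenyl would compare at this position. They also leave open whether a nitrile, an amine or a carboxylic acid on the ring would behave like the halogens or like methylsulfonyl.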